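Cyano in Place of Fluoro: What to Expect

The source may report more compounds than this note shows. Statements on the series, on what has been measured and on what is new or still open speak of the compounds shown alone.

Three compounds sharing one core have numbers in a functional assay on MCF7 cells (Homo sapiens) for antiproliferative activity, read by MTT assay, with a stated time of 72 h; a lower number here means a stronger inhibitor, a higher number a weaker inhibitor. Compound 1 `O=C(N/N=C/c1cccc(Br)c1)Nc1ccc(Oc2ccnc3[nH]ccc23)c(F)c1`, with a 3-bromophenyl group, gives 49 nM. Compound 2 `O=C(N/N=C/c1ccc(Br)cc1)Nc1ccc(Oc2ccnc3[nH]ccc23)c(F)c1`, with a 4-bromophenyl group, gives 930 nM. Compound 3 `O=C(N/N=C/c1ccc(F)cc1)Nc1ccc(Oc2ccnc3[nH]ccc23)c(F)c1`, with a 4-fluorophenyl group, gives 800 nM. Compound 3 thus sits level with compound 2, since a 1.2-fold lower number from compound 2 to compound 3 (0.07 log units; within the scatter) lies within the scatter, and far from compound 1, with a 16-fold higher number from compound 1 to compound 3 (1.21 log units; beyond the scatter).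

Compound 4 `N#Cc1ccc(/C=N/NC(=O)Nc2ccc(Oc3ccnc4[nH]ccc34)c(F)c2)cc1` has no number yet. It carries cyano in place of fluoro on an aromatic carbon. The closest evidence is the other exchange at this place, a 1.2-fold lower number from compound 2 to compound 3 (0.07 log units; within the scatter), which made no difference beyond the scatter. The large 19-fold higher number from compound 1 to compound 2 (1.28 log units; beyond the scatter) came with 4-bromophenyl in place of 3-bromophenyl, a change compound 4 does not make. Going by these compounds, this is a single comparison, and cyano itself is untested, so no step beyond the scatter is expected in this assay. The estimated step is a 1.1-fold lower number from compound 3 to compound 4 (0.06 log units; within the scatter). Compound 4 is expected near 700 nM, within an estimated range of 250 nM to 2000 nM.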

Compound 4, half-maximal inhibitory concentration: "not active" (no number reported)
Nothing numeric was reported for compound 4; no gap can be computed for the estimate.
By their numbers in this assay, from the lowest: compound 1; then compounds 3 and 2 (each within the scatter of the next).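

Among these compounds, compound 4 is reported only as "not active" in this assay, without a number, so no step from compound 3 to compound 4 can be read. No measurement shown accounts for this result. Going by these compounds, how far the 4-cyanophenyl group of compound 4 lies from the 4-fluorophenyl group of compound 3 stays open.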